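Side chain exchange on compound 2

The source may report more compounds than this note shows. Statements on the series, on what has been measured and on what is new or still open speak of the compounds shown alone.

Values in a functional assay (Nicotiana tabacum); a lower number here means a stronger inhibitor, a higher number a weaker inhibitor:
compound 1 `CSc1nc(NC2CCCC2)c2cccnc2n1`: 490 nM
compound 2 `CCCCC(CC)CNc1nc(SC)nc2ncccc12`: 15900 nM

Compound 2 stands at the higher of the two numbers, and its gap to compound 1 lies beyond the scatter. Still unmeasured is compound 3 `C=CCNc1nc(SC)nc2ncccc12`, which carries vinyl in place of 1-ethylpentyl on a saturated chain carbon bound to a nitrogen on an aromatic ring. For the measured compounds named here, no measured pair differs in one place only, so the guide is thin. Compound 1, at 490 nM, shows that a much lower number is possible on the shared core with another amine substituent. The expected change in this assay is a 3.2-fold lower number from compound 2 to compound 3 (0.50 log units; beyond the scatter), towards a lower number and beyond the scatter, though this estimate is uncertain. For compound 3 the estimated value is 5000 nM, with an expected range of 1000 nM to 25000 nM.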

Compound 3, half-maximal inhibitory concentration: 400 nM
Compound 3: the middle estimate sits 13-fold (1.10 log units) above what was measured; measured number below the stated range.
By their numbers in this assay, from the lowest: compounds 3 and 1 (each within the scatter of the next); then compound 2.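

In this assay, for the compounds shown here, vinyl in place of 1-ethylpentyl on a saturated chain carbon bound to a nitrogen on an aromatic ring gives a 40-fold lower number from compound 2 to compound 3 (1.60 log units; beyond the scatter), the first single-change reading at this position, and it shows that the high number of compound 2 goes with its 1-ethylpentyl group and not with the shared core. Allyl in place of cyclopentyl on a nitrogen on an aromatic ring gives a 1.2-fold lower number from compound 1 to compound 3 (0.09 log units; within the scatter), so among the compounds shown, the cyclopentyl ring is not required for a number of this size. Nothing measured here explains the size of the large step.

Still open, on these data alone, is whether the high number of compound 2 follows the length of the chain or its branching, which a straight butyl or straight hexyl chain would help separate. Also open, as far as these compounds go, is how an aromatic group such as benzyl on this nitrogen would compare with allyl and cyclopentyl.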